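A few compounds are considered here, and "the series" means these few. Any claim that something is new, unique, unknown or untested is made for them only; others in the source may bear on it.

Compound 3 `CC1=CC[C@@H]([C@@](C)(O)CCCC(C)(C)NC(=S)N/N=C\c2ccc(O)cc2)CC1` carries a hydroxy group on an aromatic carbon of its six-membered aromatic ring of carbon only. In a functional assay on K562 cells (Homo sapiens) for cytotoxicity, read by sulforhodamine B assay (on this read-out lower numbers stand for higher toxicity in this test and higher numbers for lower toxicity in this test), compound 3 gives > 100000 nM, which is a limit of the test and not a number. Two close relatives share the same core. Compound 1 `CC1=CC[C@@H]([C@@](C)(O)CCCC(C)(C)NC(=S)N/N=C\c2ccc(C)cc2)CC1` has a methyl on that aromatic carbon, and in this assay compound 1 gives > 100000 nM, again a limit. Compound 2 `COc1ccc(/C=N\NC(=S)NC(C)(C)CCC[C@](C)(O)[C@@H]2CC=C(C)CC2)cc1` has a methoxy on the same aromatic carbon, and in this assay compound 2 gives > 100000 nM, also a limit. The steps a step that the two limits leave unreadable from compound 1 to compound 2, a step that the two limits leave unreadable from compound 1 to compound 3 and a step that the two limits leave unreadable from compound 2 to compound 3 therefore cannot be sized, because of the limit of > 100000 nM in this assay, at which 3 of the 3 values shown sit. Compound 4 `CC1=CC[C@@H]([C@@](C)(O)CCCC(C)(C)NC(=S)N/N=C\c2ccc(N(C)C)cc2)CC1` is the next variation on this aromatic carbon: dimethylamino in place of hydroxy on an aromatic carbon. Every measured change at this carbon has left the read-out at the limit, so compound 4 is expected to remain at the limit as well, which would mean a step of a number no higher from compound 3 to compound 4 (the limit leaves the size open). Compound 4 is thus estimated to give 100000 nM in this assay, with a range from 30000 nM to 500000 nM.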

Compound 4, concentration lethal to 50% of the cells: > 100000 nM
Compound 4: only a limit was reported (the forecaster's own chance of this, stated with the estimate: 85%); the middle value sits exactly at the limit.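

In this assay compound 4 gives > 100000 nM, which is a limit and not a number. For the compounds shown here, no step to compound 4 from compound 1, compound 2 or compound 3 can therefore be read: the limit of > 100000 nM in this assay, at which 4 of the 4 values shown sit. The compounds shown leave open whether the groups on this aromatic carbon differ at all in toxicity in this test, as none of the four gives a number.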